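This account rests on a few compounds, and the source may have more. Where it says the series, first, only, none or still open, it means among the compounds named here.

The three measured compounds share one core. Compound 1 `COc1cc(C2CC(c3cccc4ccccc34)=NN2C(C)=O)ccc1OCc1cn(Cc2ccc([N+](=O)[O-])cc2)nn1` carries a naphthalen-1-yl group and in a functional assay on COLO 205 cells (Homo sapiens) for inhibition, read by sulforhodamine B assay, tested at 10 uM (a lower number here means less inhibition of growth, a higher number more inhibition of growth at the concentration tested), compound 1 gives 46%. Compound 2 `COc1cc(C2CC(c3ccc([N+](=O)[O-])cc3)=NN2C(C)=O)ccc1OCc1cn(Cc2ccc([N+](=O)[O-])cc2)nn1` gives 33%, and the step of a number 13 percentage points lower from compound 1 to compound 2 (beyond the scatter) follows the exchange of 4-nitrophenyl in place of naphthalen-1-yl on a carbon with a double bond to nitrogen. Compound 3 `COc1ccc(C2CC(c3ccc(OCc4cn(Cc5ccc([N+](=O)[O-])cc5)nn4)cc3)=NN2C(C)=O)cc1` moves the triazole-bearing ether onto the other aryl group and gives 4%, the lowest of the three values, beyond the scatter from both compound 2 and compound 1.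

Compound 4 `CC(=O)N1N=C(c2ccc(OCc3cn(Cc4ccc([N+](=O)[O-])cc4)nn3)cc2)CC1c1ccccc1` differs from compound 3 in one place: hydrogen in place of methoxy on an aromatic carbon. Among the measured compounds shown here, no measured step touches this position; the only measured step, a number 13 percentage points lower from compound 1 to compound 2 (beyond the scatter), concerns a different ring, and its modest size gives no direct guide here. Compound 3 already stands near the floor, so compound 4 is expected to stay close, with a step of a number 4 percentage points higher from compound 3 to compound 4 (within the scatter) within the scatter. For compound 4 the estimate is 8%, ranging from 0% to 25%.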

Compound 4, percent growth inhibition at one concentration: 18%
Estimate against measurement, compound 4: 10 percentage points below; measured number inside the range.
By their numbers in this assay, from the lowest: compound 3; then compound 4; then compound 2; then compound 1.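

Exchanging the 4-methoxyphenyl group for phenyl gives, in this assay, a number 14 percentage points higher from compound 3 to compound 4 (beyond the scatter), so a substituent para to a large group on this aromatic ring does affect the read-out, even though the step is modest. Among the compounds shown here, the earlier step showed only that the group on the carbon with a double bond to nitrogen matters, and it said nothing about this position. No supporting data bear on why hydrogen and methoxy differ here.

A single pair cannot show whether the size of this step depends on methoxy specifically or would recur with another group at the same place, such as a fluorine atom, a hydroxyl or an amine. It also leaves open whether the same exchange would have a comparable effect with a different group on the carbon with a double bond to nitrogen.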